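Removing One Methoxy Group From a Chalcone-Pyrazole Core

The source may report more compounds than this note shows. Statements on the series, on what has been measured and on what is new or still open speak of the compounds shown alone.

Compound 1, `COc1ccc(-c2cc(/C=C/C(=O)c3ccc(N)cc3)[nH]n2)cc1`, compound 2, `COc1ccc(-c2cc(/C=C/C(=O)c3ccc(N)cc3)[nH]n2)cc1OC`, and compound 3, `COc1cc(C(=O)/C=C/c2cc(-c3cc(OC)c(OC)c(OC)c3)n[nH]2)cc(OC)c1OC`, share a core with one free ring substituted differently. In a functional assay on UACC-62 cells (Homo sapiens) for inhibition, read by sulforhodamine B assay, with a stated time of 48 h (a lower number here means that less compound is tolerated, a higher number that more compound is tolerated), compound 1 gives 5840 nM, compound 2 gives 39600 nM and compound 3 gives 7600 nM. Compound 1 and compound 3 lie within the scatter of one another. Within the data shown here, the single change from compound 2 to compound 1 is hydrogen in place of methoxy on an aromatic carbon and it produced a 6.8-fold lower number from compound 2 to compound 1 (0.83 log units; beyond the scatter). The difference between the cores of compound 2 and compound 3 is not broken down here.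

Compound 4, `COc1ccc(-c2cc(/C=C/C(=O)c3cc(OC)c(OC)c(OC)c3)[nH]n2)cc1OC`, has not yet been measured. It arises from compound 3 by hydrogen in place of methoxy on an aromatic carbon. This is the same kind of change as that from compound 2 to compound 1, though not the same: here the carbon that loses its methoxy is also meta to a second methoxy group, which was not so before. The expected step is a 2.5-fold lower number from compound 3 to compound 4 (0.40 log units; beyond the scatter), kept smaller than the earlier step because the surroundings differ from those that gave a 6.8-fold lower number from compound 2 to compound 1 (0.83 log units; beyond the scatter). Compound 4 is thus estimated at 3000 nM in this assay, with a likely range from 1000 nM to 9000 nM.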

Compound 4, concentration lethal to 50% of the cells: 8390 nM
The estimate for compound 4 lay 2.8-fold (0.45 log units) below the measured number; the measured number falls inside the stated range.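

In this assay, putting hydrogen in place of methoxy on an aromatic carbon gave a 1.1-fold higher number from compound 3 to compound 4 (0.04 log units; within the scatter), so on this core the two numbers cannot be told apart. The change that mattered on one core therefore did not carry over to the other, and its size cannot be assumed from one core to the next in this series: the same change on two cores in this assay, a 6.8-fold lower number (0.83 log units; beyond the scatter) from compound 2 to compound 1 and a 1.1-fold higher number (0.04 log units; within the scatter) from compound 3 to compound 4, 7.5-fold (0.87 log units) apart, beyond the scatter of two such steps. Two pairs cannot show which difference between the cores sets the size of the step, nor what the change would do on any further core.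

The compounds shown leave open what a third core would give for this same change, and so whether either result is the more typical one. They also leave open whether a hydroxyl group or a chlorine atom in place of the methoxy group would separate the two cores in the same way.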